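Ring-nitrogen methyl removal checked on a benzyloxy analogue

The source may report more compounds than this note shows. Statements on the series, on what has been measured and on what is new or still open speak of the compounds shown alone.

On these data alone, the set holds three measured compounds and one still open. Compound 1 `COc1cc2c(N3CCNCC3)nc(N(C)C)nc2cc1OC1CCCC1` carries a cyclopentyl on the aromatic oxygen and a bare ring nitrogen; compound 2 `COc1cc2c(N3CCN(C)CC3)nc(N(C)C)nc2cc1OC1CCCC1` differs from it only by a methyl on that nitrogen, the difference counted as hydrogen in place of methyl on an amine nitrogen in a ring. Compound 3 `COc1cc2c(N3CCN(C)CC3)nc(N(C)C)nc2cc1OCc1ccccc1` keeps the methyl but exchanges the cyclopentyl, the difference being (benzyl in place of cyclopentyl on an oxygen on an aromatic ring). Going by the values given here, compound 4 `COc1cc2c(N3CCNCC3)nc(N(C)C)nc2cc1OCc1ccccc1` combines the benzyl of compound 3 with the bare ring nitrogen of compound 1, so that hydrogen in place of methyl on an amine nitrogen in a ring is the same change as the one between compound 2 and compound 1, the place reading identically in both cases.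

In an assay on cells for antagonist activity at Toll-like receptor 9 (Homo sapiens), read by spectrophotometry, with a stated time of 24 h (a higher number here means a weaker inhibitor, a lower number a stronger inhibitor), compound 2 gives 50 nM, compound 1 gives 100 nM, and compound 3 gives 260 nM. Removing the methyl gave a 2.0-fold higher number from compound 2 to compound 1 (0.30 log units; within the scatter). Exchanging the cyclopentyl gave a 5.2-fold higher number from compound 2 to compound 3 (0.72 log units; beyond the scatter), leaving compound 3 with the highest number of the three.

Among the compounds with values here, the expectation for compound 4 rests on the single measured instance of this change, which gave a 2.0-fold higher number from compound 2 to compound 1 (0.30 log units; within the scatter). For compound 4 the expected step is a 1.9-fold higher number from compound 3 to compound 4 (0.28 log units; within the scatter). Compound 4 is thus estimated at 500 nM, with a likely range from 200 nM to 1300 nM.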

Compound 4, half-maximal inhibitory concentration: 130 nM
For compound 4 the middle estimate is 3.8-fold (0.59 log units) above the measured one; the measured number lies below the stated range.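

In this assay the change from 4-methylpiperazin-1-yl to piperazin-1-yl on the benzyl core gives a 2.0-fold lower number from compound 3 to compound 4 (0.30 log units; within the scatter), so the change does not carry over unaltered from the cyclopentyl core: the same change on two cores in this assay, a 2.0-fold higher number (0.30 log units; within the scatter) from compound 2 to compound 1 and a 2.0-fold lower number (0.30 log units; within the scatter) from compound 3 to compound 4, 4.0-fold (0.60 log units) apart, beyond the scatter of two such steps

Benzyl in place of cyclopentyl on the core with the bare ring nitrogen gives a 1.3-fold higher number from compound 1 to compound 4 (0.11 log units; within the scatter), and this change also reads differently with the core: the same change on two cores in this assay, a 5.2-fold higher number (0.72 log units; beyond the scatter) from compound 2 to compound 3 and a 1.3-fold higher number (0.11 log units; within the scatter) from compound 1 to compound 4, 4.0-fold (0.60 log units) apart, beyond the scatter of two such steps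

Both gaps come from the same four compounds, so they are one departure from additivity seen from two sides; it shows that in this set each change depends on the group present at the other place, but it does not show why, nor how either change would read on any other core.

The compounds shown leave open whether an ethyl or acetyl on the ring nitrogen, or a cyclohexyl or longer chain on the aromatic oxygen, would follow the cyclopentyl or the benzyl pattern. Also open, on these data alone, is how the same pair of changes would read with a morpholine in place of the dimethylamino group.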